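N-Methylation of the Fused Ring Hydrogen in Compound 1

The compounds below may be only part of what the source reports. "The series", "measured", "known", "first", "only" and "open" are said of these compounds alone.

Within the data shown here, compound 1 `COc1ccc(-n2ccc(=O)c(C(=O)Nc3ccc(Oc4ccnc5[nH]ccc45)c(F)c3)n2)cc1` has the higher of the two numbers recorded in a functional assay on PC-3 cells (Homo sapiens) for cytotoxicity, read by MTT assay, with a stated time of 72 h (on this read-out higher numbers stand for weaker inhibition and lower numbers for stronger inhibition), where compound 1 gives 46400 nM; its only neighbour, compound 2 `O=C(Nc1ccc(Oc2ccnc3[nH]ccc23)c(F)c1)c1nn(-c2ccc(Br)cc2F)ccc1=O`, gives 8800 nM, and the step from compound 1 to compound 2 is a 5.3-fold lower number from compound 1 to compound 2 (0.72 log units; beyond the scatter). Compound 3 `COc1ccc(-n2ccc(=O)c(C(=O)Nc3ccc(Oc4ccnc5c4ccn5C)c(F)c3)n2)cc1` differs from compound 1 by methyl in place of hydrogen on an aromatic nitrogen. Among the measured compounds shown here, that measured step alters a different position, so no step bears on this change, and the record gives no guide. Compound 3 is therefore expected to stay close to compound 1, with a step of a 1.3-fold higher number from compound 1 to compound 3 (0.11 log units; within the scatter) estimated in this assay. Compound 3 is estimated at 60000 nM, within 20000 nM to 150000 nM.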

Compound 3, half-maximal inhibitory concentration: > 60000 nM
Compound 3 ended at the assay's limit (the forecaster's own chance of this, stated with the estimate: 30%); the middle value lies on the limit itself.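

Among these compounds, this is the first reading at the aromatic nitrogen of the five-membered ring: in this assay, methyl in place of hydrogen there brought no lower number, the step being an at least 1.2-fold higher number from compound 1 to compound 3 (0.11 log units; that floor lies within the scatter). That step is only a floor, so its true size stays unread. Compound 3 stands at a limit of the assay, not at a number: the limit of > 60000 nM in this assay, at which 1 of the 3 values shown sits.

Open, as far as these compounds go, is whether an ethyl group, a longer chain or a chain ending in an amine on this nitrogen would behave the same way. Also open, from the compounds shown here alone, is whether methyl there would do so alongside the 4-bromo-2-fluorophenyl of compound 2.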